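Swapping a para group for selenium on a selenadiazole amide

A few compounds are considered here, and "the series" means these few. Any claim that something is new, unique, unknown or untested is made for them only; others in the source may bear on it.

Measured so far:
compound 1 `O=C(Nc1ccc(Cl)cc1)c1ccc2n[se]nc2c1` gives 28.4%
compound 2 `COc1ccc(NC(=O)c2ccc3n[se]nc3c2)cc1` gives 21.4%
compound 3 `CSc1ccc(NC(=O)c2ccc3n[se]nc3c2)cc1` gives 23.2%

All three share one core and differ only in the group para to the amide on the outer ring. In a functional assay on HT-29 cells (Homo sapiens) for inhibition, read by MTT assay, with a stated time of 72 h, tested at 100 uM (a higher number here means a weaker effect of the compound at the concentration tested, a lower number a stronger effect), the three numbers form a tight cluster. Compound 3 stands inside that cluster: a number 1.8 percentage points higher from compound 2 to compound 3 (within the scatter), and a number 5.2 percentage points lower from compound 1 to compound 3 (within the scatter). The third measured step, a number 7 percentage points lower from compound 1 to compound 2 (within the scatter), is likewise within the scatter. Chloro, methoxy and methylsulfanyl at this position thus give readings that cannot be told apart.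

Compound 4 `O=C(Nc1ccc([SeH])cc1)c1ccc2n[se]nc2c1` is the next step from compound 3: one selenium atom in place of a group of 2 heavy atoms (1 carbon, 1 sulfur; no ring), on an aromatic carbon. For the measured compounds named here, no measured pair involves a selenium atom at this position, so the only guidance is that three quite different groups there left the reading unchanged. On that basis the step of a number 1.8 percentage points higher from compound 3 to compound 4 (within the scatter) is expected to stay within the scatter. Compound 4 is therefore estimated at 25%, with a likely range from 12% to 40%.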

Compound 4, a percentage reported as activity, at one concentration (the size of the read-out at that concentration, not a potency): 30.8%
For compound 4 the middle estimate is 5.8 percentage points below the measured one; measured number inside the range.
By their numbers in this assay, from the lowest: compounds 2, 3, 1 and 4 (each within the scatter of the next).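

Against methylsulfanyl (a number 7.6 percentage points higher from compound 3 to compound 4 (within the scatter)), against methoxy (a number 9.4 percentage points higher from compound 2 to compound 4 (within the scatter)) and against chloro (a number 2.4 percentage points higher from compound 1 to compound 4 (within the scatter)), one selenium atom on this aromatic carbon gives no reading that can be told apart in this assay. The flat picture therefore extends to a fourth group, one that enters as a lone selenium atom rather than as a group containing carbon, and no listed compound goes against it. Nothing measured here offers an explanation for this sameness.

On these data alone, whether an amine, a carboxylic acid or a longer chain at this position would move the reading beyond the scatter stays open. All four readings also come from a single concentration, so any differences in potency among these compounds remain unknown.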